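A few compounds are considered here, and "the series" means these few. Any claim that something is new, unique, unknown or untested is made for them only; others in the source may bear on it.

Working notes on a hydroxybenzamide series read in a functional assay on KG-1 cells (Homo sapiens) for cytotoxicity, read by luminescence and CellTiter-Glo, with a stated time of 3 days; on this read-out lower numbers stand for stronger inhibition and higher numbers for weaker inhibition.

Three compounds carry the same fluorinated salicylamide half and differ only on the anilide ring. Compound 1 `O=C(Nc1ccc([N+](=O)[O-])cc1)c1cc(F)ccc1O` bears a nitro group and in this assay gives 1100 nM. Compound 2 `O=C(Nc1cccc(C(F)(F)F)c1)c1cc(F)ccc1O` bears a trifluoromethyl group in place of that and in this assay gives 1010 nM; these two numbers lie within the scatter of each other. The difference between the core of compound 1 and the core of compound 2 is not broken down here. Compound 3 `O=C(Nc1ccc(Cl)c(C(F)(F)F)c1)c1cc(F)ccc1O` adds a chlorine to compound 2. In this assay compound 3 gives 540 nM. The change from compound 2 to compound 3 is chloro in place of hydrogen on an aromatic carbon and made a 1.9-fold lower number from compound 2 to compound 3 (0.27 log units; within the scatter). Compound 3 sits beyond the scatter from compound 1 and within it from compound 2.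

Compound 4 `O=C(Nc1ccc([N+](=O)[O-])cc1Cl)c1cc(F)ccc1O` has not yet been measured. It relates to compound 1 as compound 3 relates to compound 2: chloro in place of hydrogen on an aromatic carbon. The two places are not identical, since in compound 3 the chlorine sits ortho to a trifluoromethyl group and para to a large group, whereas in compound 4 it sits ortho to a large group and meta to a nitro group, so this is the same kind of change rather than the same change. Among the measured compounds shown here, with only one prior example, the step from compound 1 to compound 4 is expected to be of the order of a 1.7-fold lower number from compound 1 to compound 4 (0.23 log units; within the scatter), resting on compound 2 to compound 3 having given a 1.9-fold lower number from compound 2 to compound 3 (0.27 log units; within the scatter). Compound 4 is therefore estimated at 650 nM, with a range of 300 nM to 1500 nM.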

Compound 4, half-maximal inhibitory concentration: 490 nM
For compound 4 the middle estimate is 1.3-fold (0.12 log units) above the measured one; measured number inside the range.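

In this assay, chloro in place of hydrogen on an aromatic carbon gives a 2.2-fold lower number from compound 1 to compound 4 (0.35 log units; beyond the scatter), and this step matches the earlier one on the other core: the same change on two cores in this assay, a 1.9-fold lower number (0.27 log units; within the scatter) from compound 2 to compound 3 and a 2.2-fold lower number (0.35 log units; beyond the scatter) from compound 1 to compound 4, 1.2-fold (0.08 log units) apart, within the scatter of two such steps

Among the compounds shown here, on these two cores, then, the change carries over at a similar size, although only the step on the core of compound 1 lies beyond the scatter, and only modestly so. This does not show that the change transfers generally: there are just two examples, one of them within the scatter, and the chlorine does not occupy the same place in both, since in compound 4 it sits ortho to a large group and meta to a nitro group, so any contribution of place cannot be separated from that of the core.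

The compounds shown leave open whether chlorine in one matched place on both cores would give matching steps, and whether the step would hold on a core carrying neither nitro nor trifluoromethyl. They also leave open whether a bromine, a methyl or a methoxy group in the place of the chlorine would give a step of similar size, or whether an amine there would behave differently.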